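Two Changes on One Shared Core, Three Measurements

A few compounds are considered here, and "the series" means these few. Any claim that something is new, unique, unknown or untested is made for them only; others in the source may bear on it.

Three of the four compounds in this set have been measured. Compound 1 `O=C(NCc1ccc(CNS(=O)(=O)c2cccc(F)c2)cc1)c1cccnc1` gives 1000 nM in an assay on MDA-MB-231 cells for displacement of a labelled ligand from C-X-C chemokine receptor type 4 (Homo sapiens), read by fluorescence and microscopy, with stated times of 10 min and 30 min; a lower number here means that less compound is needed, a higher number that more compound is needed for the effect. Compound 2 `COc1ccccc1C(=O)NCc1ccc(CNS(=O)(=O)c2cccc(F)c2)cc1` differs from compound 1 by 2-methoxyphenyl in place of pyridin-3-yl on a carbonyl carbon, and in this assay compound 2 gives 1000 nM; the step is no change at the digits printed from compound 1 to compound 2 (within the scatter). Compound 3 `O=C(NCc1ccc(CNS(=O)(=O)c2ccc(Cl)cc2)cc1)c1cccnc1` differs from compound 1 by 4-chlorophenyl in place of 3-fluorophenyl on a sulfonyl sulfur, and in this assay compound 3 gives 1000 nM; the step is no change at the digits printed from compound 1 to compound 3 (within the scatter).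

Compound 4 `COc1ccccc1C(=O)NCc1ccc(CNS(=O)(=O)c2ccc(Cl)cc2)cc1` awaits measurement. It differs from compound 3 by 2-methoxyphenyl in place of pyridin-3-yl on a carbonyl carbon, the same change that was made from compound 1 to compound 2, where the step was no change at the digits printed from compound 1 to compound 2 (within the scatter). The two cores on which the change is made differ by 4-chlorophenyl in place of 3-fluorophenyl on a sulfonyl sulfur, while the place of the change is described in the same words for both pairs.

Among the compounds with values here, because the first instance of this change gave no change at the digits printed from compound 1 to compound 2 (within the scatter), and because compound 3 stands at 1000 nM, compound 4 is expected to stay level, with an estimated step of no change at the digits printed from compound 3 to compound 4 (within the scatter). Compound 4 is therefore estimated at 1000 nM in this assay, between 500 nM and 2000 nM.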

Compound 4, effective concentration (reported as EC, without a stated level of effect): 1000 nM
Beside the measured number, compound 4's estimate shows no gap at the digits printed; the range from low to high includes it.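

In this assay, 2-methoxyphenyl in place of pyridin-3-yl on a carbonyl carbon gives no change at the digits printed from compound 3 to compound 4 (within the scatter), and this second instance matches the first: the same change on two cores in this assay, no change at the digits printed (within the scatter) from compound 1 to compound 2 and no change at the digits printed (within the scatter) from compound 3 to compound 4, 1.0-fold (0.00 log units) apart, within the scatter of two such steps. The other change, 4-chlorophenyl in place of 3-fluorophenyl on a sulfonyl sulfur, gives no change at the digits printed from compound 2 to compound 4 (within the scatter), and it too matches its earlier instance: the same change on two cores in this assay, no change at the digits printed (within the scatter) from compound 1 to compound 3 and no change at the digits printed (within the scatter) from compound 2 to compound 4, 1.0-fold (0.00 log units) apart, within the scatter of two such steps. Each change therefore leaves the reading level on both cores shown, but this is only the repetition of a flat step, and it does not show how a change that moved the value would carry from one core to another, nor does it reach beyond these four compounds.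

On these data alone, all four compounds share one printed value, so what on the shared core would move the reading remains open. Whether an amine or a carboxylic acid in place of the 2-methoxyphenyl or the 4-chlorophenyl would shift the result in this assay is also left open.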